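A new aryl group on the sulfonyl sulfur

This account rests on a few compounds, and the source may have more. Where it says the series, first, only, none or still open, it means among the compounds named here.

Compound 1 `CCn1cc(C(=O)O)c(=O)c2cc(F)c(N3CCN(C(=N)NS(=O)(=O)c4ccccc4Cl)CC3)cc21`: 71 nM
Compound 2 `CCn1cc(C(=O)O)c(=O)c2cc(F)c(N3CCN(C(=N)NS(=O)(=O)c4ccccc4C(F)(F)F)CC3)cc21`: 71 nM

Measured in a functional assay on A549 cells (Homo sapiens) for antiproliferative activity, read by MTT assay, with a stated time of 72 h (on this read-out lower numbers stand for stronger inhibition and higher numbers for weaker inhibition), compound 2 gives 71 nM and stands level with compound 1. The next molecule is compound 3 `CCn1cc(C(=O)O)c(=O)c2cc(F)c(N3CCN(C(=N)NS(=O)(=O)c4ccc(C)cc4)CC3)cc21`, and the change is 4-methylphenyl in place of 2-(trifluoromethyl)phenyl on a sulfonyl sulfur. Within the data shown here, only one measured step bears on this, no change at the digits printed from compound 1 to compound 2 (within the scatter), where trifluoromethyl replaced chloro on an aromatic carbon. Among the measured compounds shown here, that swap stayed within the scatter, but no measured compound carries the 4-methylphenyl group, so the guidance is thin. Resting on no change at the digits printed from compound 1 to compound 2 (within the scatter), no step beyond the scatter is expected in this assay, in either direction. The expected step is a 1.1-fold higher number from compound 2 to compound 3 (0.05 log units; within the scatter). The estimated value for compound 3 is 80 nM, with an expected range from 30 nM to 210 nM.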

Compound 3, half-maximal inhibitory concentration: 71 nM
The estimate for compound 3 lay 1.1-fold (0.05 log units) above the measured number; measured number inside the range.
By their numbers in this assay, from the lowest: compounds 1, 2 and 3 (each within the scatter of the next).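

In this assay, moving to the 4-methylphenyl group gives no change at the digits printed from compound 2 to compound 3 (within the scatter), and the comparison with the 2-chlorophenyl group gives no change at the digits printed from compound 1 to compound 3 (within the scatter). Among these compounds, the earlier pair showed only that one group could replace another on the same 2-substituted phenyl; these steps extend that result to a phenyl group with a different substituent, numbered at a different ring position, so all three aryl groups on the sulfonyl sulfur read alike here. No evidence is available to explain why these three groups give matching numbers.

From the compounds shown here alone, it remains open whether the same holds for a phenyl ring bearing an amine or a carboxylic acid. A straight alkyl chain on the sulfonyl sulfur in place of the aryl ring is equally untested by these three compounds.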